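The compounds below may be only part of what the source reports. "The series", "measured", "known", "first", "only" and "open" are said of these compounds alone.

Measured compounds in a functional assay on Caco-2 cells (Homo sapiens) for inhibition, read by MTT assay, with a stated time of 48 h; on this read-out lower numbers stand for stronger inhibition and higher numbers for weaker inhibition:
Compound 1 `COc1cc(/C=N/Nc2nc(-c3ccc(C(F)(F)F)cc3)cs2)c(Br)c(Br)c1OC` gives > 100000 nM, which is a limit of the assay and not a number.
Compound 2 `COc1cc(/C=N/Nc2nc(-c3ccc(F)c(F)c3)cs2)cc(Br)c1OC` gives 21200 nM.
Compound 3 `COc1cc(/C=N/Nc2nc(-c3ccc(F)c(F)c3)cs2)c(Br)c(Br)c1OC` gives 22800 nM.

Compound 3 has the highest of the two numbers, with compound 2 nearest; the gap is a 1.1-fold higher number from compound 2 to compound 3 (0.03 log units; within the scatter), so the two are not distinguishable. Compound 1 contributes only a limit.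

Compound 4 `COc1cc(/C=N/Nc2nc(-c3ccccc3)cs2)c(Br)c(Br)c1OC` differs from compound 3 by phenyl in place of 3,4-difluorophenyl on an aromatic carbon. Within the data shown here, the one measured step at this position is an at least 4.3-fold lower number from compound 1 to compound 3 (0.64 log units; beyond the scatter), which shows that the group on this carbon can move the read-out by at least a modest amount; the step of a 1.1-fold higher number from compound 2 to compound 3 (0.03 log units; within the scatter) concerns the bromo substituent elsewhere and bears little on the present change. Among the measured compounds shown here, no measured pair isolates the loss of the two fluorines from a 3,4-difluorophenyl. Given the size of the aryl effect seen in an at least 4.3-fold lower number from compound 1 to compound 3 (0.64 log units; beyond the scatter) and the absence of a closer comparison, a modest weakening or no change beyond the scatter is expected for compound 4, with a 1.5-fold higher number from compound 3 to compound 4 (0.19 log units; within the scatter) as the estimated step. Compound 4 is therefore expected to give about 35000 nM, within a range from 12000 nM to 100000 nM.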

Compound 4, half-maximal inhibitory concentration: 26500 nM
Compound 4: middle estimate off by 1.3-fold (0.12 log units), on the high side, within the range that was stated.
By their numbers in this assay, from the lowest: compounds 2, 3 and 4 (each within the scatter of the next). At a limit, above all of these: compound 1.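

In this assay, phenyl and 3,4-difluorophenyl on this carbon of the five-membered ring cannot be told apart, with a 1.2-fold higher number from compound 3 to compound 4 (0.07 log units; within the scatter) as the step, so on the core of compound 3 the two fluorines have no readable effect on the number. The step beyond the scatter at this position now separates 4-(trifluoromethyl)phenyl from both other aryl groups, as the unsubstituted phenyl also shows, with an at least 3.7-fold lower number from compound 1 to compound 4 (0.57 log units; beyond the scatter) as its size. As far as these compounds go, the true size of that step stays unknown because compound 1 stands at a limit of the assay and not at a number: the limit of > 100000 nM in this assay, at which 1 of the 4 values shown sits.

Still open, from the compounds shown here alone, is whether the separation belongs to trifluoromethyl alone or would also appear with another group on the phenyl, such as a methoxy, an amine or a carboxylic acid. Also open, going by these compounds, is whether anything on this carbon gives a number well below those of compound 3 and compound 4, for example a pyridine or a saturated cyclohexyl ring in place of the phenyl.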